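The source may hold more compounds than are shown below. What is called first, only, known or untested is meant among the compounds shown, and "the series" means these compounds.

Measured so far:
compound 1, `COCC(=O)Nc1c(C(O)(C(F)(F)F)C(F)(F)F)ccc2ccccc12`: 213 nM in an assay on LtK cells with ATP-sensitive inward rectifier potassium channel 11 (Homo sapiens) as the target; on this read-out lower numbers stand for an effect already at smaller amounts and higher numbers for an effect only at larger amounts of compound
compound 2, `O=C(Nc1c(C(O)(C(F)(F)F)C(F)(F)F)ccc2ccccc12)c1ccc(Cl)cc1`: 570 nM in this assay

Of these two numbers compound 2 shows the higher one; its nearest neighbour is compound 1, and the step of a 2.7-fold higher number from compound 1 to compound 2 (0.43 log units; beyond the scatter) lies between them. Compound 3, `O=C(Nc1c(C(O)(C(F)(F)F)C(F)(F)F)ccc2ccccc12)c1ccc(Br)cc1`, is not yet measured. Its change from compound 2 is bromo in place of chloro on an aromatic carbon, one halogen exchanged for another on the ring that sits on the carbonyl carbon. Within the data shown here, the only measured step, a 2.7-fold higher number from compound 1 to compound 2 (0.43 log units; beyond the scatter), replaces the whole group on the carbonyl carbon and so does not speak to a halogen swap on that ring; no measured pair bears on this change. In this assay the step expected from this swap is a 1.1-fold higher number from compound 2 to compound 3 (0.02 log units; within the scatter), which is not beyond the scatter, in no clear direction. For compound 3 the estimated value is 600 nM, with a range from 300 nM to 1200 nM.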

Compound 3, half-maximal effective concentration: 47 nM
Compound 3: middle estimate off by 13-fold (1.11 log units), on the high side; measured number below the stated range.
By their numbers in this assay, from the lowest: compound 3; then compound 1; then compound 2.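

In this assay, among these compounds, the swap of chloro for bromo on the ring, para to a large group, adds no ring, hydrogen-bond donor, hydrogen-bond acceptor or charge, yet it gives a 12-fold lower number from compound 2 to compound 3 (1.08 log units; beyond the scatter), so this position is far more sensitive to the choice of halogen than the earlier compounds could show. It also changes how the 4-halophenyl amides compare with the methoxymethyl amide: the 4-chlorophenyl group gave a 2.7-fold higher number from compound 1 to compound 2 (0.43 log units; beyond the scatter), whereas the 4-bromophenyl group gives a 4.5-fold lower number from compound 1 to compound 3 (0.66 log units; beyond the scatter). No measurement shown here accounts for the size of this step.

As far as these compounds go, with only chloro and bromo at this position, it remains open where iodo, fluoro or a plain hydrogen would fall. From the compounds shown here alone, it also remains open whether a non-halogen group there, such as methyl or nitrile, would give a number closer to that of bromo or chloro.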